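A few compounds are considered here, and "the series" means these few. Any claim that something is new, unique, unknown or untested is made for them only; others in the source may bear on it.

In a functional assay on the whole organism (strain Wister albino) for inhibition, with Rattus norvegicus as the target, read by paw edema, with stated times of 30 min and 3 h, at a dose of 10 mg/kg by the oral route (on this read-out lower numbers stand for less inhibition and higher numbers for more inhibition at the one dose given (going by the name of the read-out)), three compounds have been measured:
compound 1 `CC(C)Cc1ccc(C(C)c2nn(CN3CCN(c4cccc(Cl)c4)CC3)c(=S)o2)cc1` gives 64.3%;
compound 2 `CC(C)Cc1ccc(C(C)c2nn(CN3CCN(c4ccc([N+](=O)[O-])cc4)CC3)c(=S)o2)cc1` gives 75.1%;
compound 3 `CC(C)Cc1ccc(C(C)c2nn(CN3CCN(c4ccc(F)cc4)CC3)c(=S)o2)cc1` gives 75.4%.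

Compound 3 carries the highest number of the three, but its gap to compound 2 is within the scatter, so these two cannot be told apart; only compound 1 lies clearly below. The next compound is compound 4 `CCOc1ccccc1N1CCN(Cn2nc(C(C)c3ccc(CC(C)C)cc3)oc2=S)CC1`, which differs from compound 3 in one place: 2-ethoxyphenyl in place of 4-fluorophenyl on an amine nitrogen in a ring. Among the measured compounds shown here, two measured steps concern a swap of the group on an amine nitrogen in a ring, as here: a number 11.1 percentage points higher from compound 1 to compound 3 (beyond the scatter) and a number 10.8 percentage points higher from compound 1 to compound 2 (beyond the scatter), both modest rises. The third step, a number 0.3 percentage points higher from compound 2 to compound 3 (within the scatter), shows that a swap on an aromatic carbon of that group can also leave the read-out unchanged. For the measured compounds named here, no measured compound carries a 2-ethoxyphenyl, so the direction of this step cannot be read from the data. The expected step is therefore a number 5.4 percentage points lower from compound 3 to compound 4 (within the scatter), within the scatter. Compound 4 is expected to give about 70%, between 57% and 81%.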

Compound 4, a percentage reported as inhibition, in the whole organism at one dose (the size of the read-out at that dose, not a potency): 44.6%
For compound 4 the middle estimate is 25.4 percentage points above the measured one; the whole stated range lies above it.
By their numbers in this assay, from the lowest: compound 4; then compound 1; then compounds 2 and 3 (each within the scatter of the next).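

In this assay, the group on this ring nitrogen can do more than leave the read-out unchanged or shift it modestly: 2-ethoxyphenyl in place of the earlier aryl groups gives a number 30.8 percentage points lower from compound 3 to compound 4 (beyond the scatter) and a number 30.5 percentage points lower from compound 2 to compound 4 (beyond the scatter) and also a number 19.7 percentage points lower from compound 1 to compound 4 (beyond the scatter) even though compound 1 was already the lowest of the earlier three. Among the compounds shown here, this position is therefore more sensitive to the choice of group than the earlier compounds showed, and it is compound 4 that sets the low end of the series. The entering group has 9 heavy atoms against 7 for 4-fluorophenyl and has 1 hydrogen-bond acceptor against 0, but no measurement here links either difference to the fall.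

For the compounds shown here, with only one compound of this kind, the ethoxy group itself cannot be separated from its place on the phenyl ring. A plain phenyl, or a methoxy group in place of the ethoxy, would help to tell these apart.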